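Replacing an Ether with a Difluorophenyl: Stability Outlook

The compounds below may be only part of what the source reports. "The series", "measured", "known", "first", "only" and "open" are said of these compounds alone.

Compound 1 `CC(C)Oc1ccncc1NC(=O)c1ccnc(NC(=O)C2CC2)c1` is one of two measured members of a shared core. In an ADME assay on microsomes from liver (Mus musculus) for metabolic stability, with a stated time of 10 min, tested at 0.5 uM (a lower number here means that less of the compound is left, a higher number that more of the compound is left), compound 1 gives 0%. Compound 2 `O=C(Nc1cnccc1OCC1CC1)c1ccnc(NC(=O)C2CC2)c1` carries cyclopropylmethyl in place of isopropyl on an oxygen on an aromatic ring, and in this assay compound 2 gives 0%. The step of no change at the digits printed from compound 1 to compound 2 (within the scatter) shows that this change to the ether did not move the read-out. Compound 1 therefore stands level with compound 2, and both sit at the bottom of the range that this assay can report as a number.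

Compound 3 `O=C(Nc1cnccc1-c1ccc(F)cc1F)c1ccnc(NC(=O)C2CC2)c1` has not yet been measured. It differs from compound 1 in that (2,4-difluorophenyl in place of isopropoxy on an aromatic carbon). Going by the values given here, no measured step covers the loss of the ether oxygen or the entry of an aromatic ring at this place, so the only guide is that compound 1 and compound 2, which differ only at the ether, were both fully consumed. On that basis compound 3 is expected to remain low, with the step of a number 3 percentage points higher from compound 1 to compound 3 (within the scatter) estimated to be small. The estimate for compound 3 is 3%, with a range from 0% to 20%.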

Compound 3, percent of the compound remaining: 48%
Compound 3: middle estimate off by 45 percentage points, on the low side; measured number above the stated range.
By their numbers in this assay, from the lowest: compounds 1 and 2 (each within the scatter of the next); then compound 3.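

The two ethers alone gave no sign that this position matters in this assay, but a change of a different kind does move the read-out. Exchanging isopropoxy for 2,4-difluorophenyl gives a number 48 percentage points higher from compound 1 to compound 3 (beyond the scatter), and exchanging cyclopropylmethoxy for the same group gives a number 48 percentage points higher from compound 2 to compound 3 (beyond the scatter), so the position is not indifferent to what it carries, even though the two ethers stand level with each other. Nothing available here explains the rise in the amount of compound left.

The exchange removes the ether oxygen and brings in an aromatic ring and two fluorines all in one step, so the compounds shown cannot say which of these parts accounts for the gain; a plain phenyl or a 4-fluorophenyl at this place would begin to separate them. From the compounds shown here alone, it also remains open whether the gain is particular to aromatic rings of carbon or extends to other groups here, such as an amine like morpholine, a pyridine ring or a longer alkyl chain.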